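Fluoro for methyl across two cores of one series

The source may hold more compounds than are shown below. What is called first, only, known or untested is meant among the compounds shown, and "the series" means these compounds.

Measured compounds:
- compound 1, `Cc1ccccc1COc1ccc(-c2cc(CN3CCN(Cc4ccc(C(F)(F)F)cc4)CC3)no2)cc1`: 1200 nM
- compound 2, `Fc1ccccc1COc1ccc(-c2cc(CN3CCN(Cc4ccc(C(F)(F)F)cc4)CC3)no2)cc1`: 1500 nM
- compound 3, `Cc1cc(-c2cc(CN3CCN(Cc4ccc(C(F)(F)F)cc4)CC3)no2)ccc1OCc1cccc(C#N)c1`: 600 nM

In a functional assay on Huh-7 cells (Homo sapiens) for antiproliferative activity, read by sulforhodamine B assay, with a stated time of 72 h (a lower number here means a stronger inhibitor, a higher number a weaker inhibitor), compound 1 and compound 2 differ by fluoro in place of methyl on an aromatic carbon and gave a 1.3-fold higher number from compound 1 to compound 2 (0.10 log units; within the scatter). Compound 3 carries a different core; the difference between the two cores is not broken down here. Compound 4, `N#Cc1cccc(COc2ccc(-c3cc(CN4CCN(Cc5ccc(C(F)(F)F)cc5)CC4)no3)cc2F)c1`, is not yet measured and differs from compound 3 by fluoro in place of methyl on an aromatic carbon. This is the same kind of change as that from compound 1 to compound 2, though here the place is ortho to a (3-cyanobenzyl)oxy group and meta to a large group rather than ortho to a large group. Because the earlier step of a 1.3-fold higher number from compound 1 to compound 2 (0.10 log units; within the scatter) was small, a step of similar size, a 1.3-fold higher number from compound 3 to compound 4 (0.10 log units; within the scatter), is expected from compound 3 to compound 4. Compound 4 is estimated at 750 nM, between 350 nM and 1600 nM.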

Compound 4, half-maximal inhibitory concentration: 90 nM
The estimate for compound 4 lay 8.3-fold (0.92 log units) above the measured number, outside the stated range (below it).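

In this assay, fluoro in place of methyl on an aromatic carbon gave a 6.7-fold lower number from compound 3 to compound 4 (0.82 log units; beyond the scatter). The size of this step did not carry over from one core to the other: the same change on two cores in this assay, a 1.3-fold higher number (0.10 log units; within the scatter) from compound 1 to compound 2 and a 6.7-fold lower number (0.82 log units; beyond the scatter) from compound 3 to compound 4, 8.3-fold (0.92 log units) apart, beyond the scatter of two such steps. With a single pair on each core, the data do not separate the effect of the core from that of the place of the change, ortho to a (3-cyanobenzyl)oxy group in compound 4, or from that of the nitrile, and they give no reason for the gap.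

Still open, going by these compounds, is whether chloro or methoxy at that place would give a step like that to compound 4. Also open, on these data alone, is whether the nitrile can give way to a carboxylic acid or an amide without losing that step.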